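This account rests on a few compounds, and the source may have more. Where it says the series, first, only, none or still open, it means among the compounds named here.

Four compounds built on a shared pattern, a cyclic disulfide amide joined through a chain to a halogen-bearing phenyl ring on a fused core, are considered here. Compound 1 `O=C(CCCCC1CCSS1)NCc1cn(CCCOc2ccc3cc(-c4ccc(Br)cc4)c(=O)oc3c2)nn1` was tested in a functional assay on PC-12 cells (Rattus norvegicus) for cytotoxicity, read by MTT assay, with stated times of 3 h and 2 h, tested at 5 uM (on this read-out lower numbers stand for a weaker effect and higher numbers for a stronger effect at the one concentration tested), where compound 1 gives 57.3%. Compound 2 `O=C(CCCCC1CCSS1)NCc1cn(CCCOc2ccc3cc(-c4ccc(Cl)c(Cl)c4)c(=O)oc3c2)nn1` differs from compound 1 in one place only: 3,4-dichlorophenyl in place of 4-bromophenyl on an aromatic carbon. In this assay compound 2 gives 44.7%, a step of a number 12.6 percentage points lower from compound 1 to compound 2 (beyond the scatter).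

Compound 3 `O=C(CCCCC1CCSS1)NCc1cn(CCCCCOc2ccc3cc(-c4ccc(Br)cc4)c(=O)oc3c2)nn1` carries a core that differs from that of compound 1; the difference between the two cores is not broken down here. In this assay compound 3 gives 45.7%, which sits within the usual scatter of the value of compound 2 while lying beyond the scatter below the value of compound 1.

Compound 4 `O=C(CCCCC1CCSS1)NCc1cn(CCCCCOc2ccc3cc(-c4ccc(Cl)c(Cl)c4)c(=O)oc3c2)nn1` has not yet been measured. It relates to compound 3 by 3,4-dichlorophenyl in place of 4-bromophenyl on an aromatic carbon, the same change that turned compound 1 into compound 2, made at the same place. Because the earlier step was a number 12.6 percentage points lower from compound 1 to compound 2 (beyond the scatter), a step of similar size is expected here, namely a number 12.7 percentage points lower from compound 3 to compound 4 (beyond the scatter). On that basis compound 4 is estimated to give 33% in this assay, expected to fall between 24% and 44%.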

Compound 4, a percentage reported as activity, at one concentration (the size of the read-out at that concentration, not a potency): 54.8%
The estimate for compound 4 lay 21.8 percentage points below the measured number, and the stated range ends below it.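

On the core of compound 3, putting 3,4-dichlorophenyl in place of 4-bromophenyl gives, in this assay, a step of a number 9.1 percentage points higher from compound 3 to compound 4 (within the scatter), so no real effect of the change can be claimed on this core. Set beside the earlier step, the change does not carry over from one core to the other with the same result: the same change on two cores in this assay, a number 12.6 percentage points lower (beyond the scatter) from compound 1 to compound 2 and a number 9.1 percentage points higher (within the scatter) from compound 3 to compound 4, 21.7 percentage points apart, beyond the scatter of two such steps This shows that, for these two pairs of compounds, the outcome of the swap cannot simply be transferred between cores, but it does not show which feature of the cores is responsible, nor does it give a rule for any other core.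

The compounds shown leave open how an unsubstituted phenyl, a 4-methoxyphenyl or a 4-chlorophenyl ring would behave on either core. From the compounds shown here alone, it also remains open whether the same picture would appear at other concentrations, as each compound is represented here by a single reading.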